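Dropping a Methylene: From Compound 2 to Compound 4

The source may hold more compounds than are shown below. What is called first, only, known or untested is meant among the compounds shown, and "the series" means these compounds.

The three compounds measured so far in an ADME assay on RAW264.7 cells (Mus musculus) for cytotoxicity, read by MTT assay, with a stated time of 72 h, tested at 100 uM; a higher number here means a stronger effect of the compound at the concentration tested, a lower number a weaker effect:

compound 1 `O=C(Cn1c(=O)oc2cc(Cl)ccc21)Nc1nc2ccccc2s1` gives 52.5%
compound 2 `O=C(Cn1c(=O)oc2cc([N+](=O)[O-])ccc21)NCc1ccccn1` gives 33.4%
compound 3 `O=C(Cn1c(=O)oc2cc([N+](=O)[O-])ccc21)Nc1cc(C(F)(F)F)ccc1Cl` gives 31.6%

Among these three numbers compound 2 stands second highest. Its nearest neighbour is compound 3, whose value sits slightly lower but within the usual scatter, so the two cannot be told apart. Compound 1 lies furthest away, higher by an amount beyond the scatter.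

Compound 4 `O=C(Cn1c(=O)oc2cc([N+](=O)[O-])ccc21)Nc1ccccn1` has not yet been measured in this assay. It differs from compound 2 in one place: pyridin-2-yl in place of (pyridin-2-yl)methyl on an amide-type nitrogen. The amide nitrogen now carries the ring directly rather than through a one-carbon link.

For the measured compounds named here, nothing among the measured pairs shows the effect of this exact change, so the expectation rests on how closely compounds 2 and 3 agree. The step of a number 1.6 percentage points higher from compound 2 to compound 4 (within the scatter) is expected to be small, with no clear direction, and to stay within the scatter. Compound 4 is expected to give about 35%, most likely between 22% and 50%.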

Compound 4, a percentage reported as inhibition, at one concentration (the size of the read-out at that concentration, not a potency): 47.3%
For compound 4 the middle estimate is 12.3 percentage points below the measured one, within the range that was stated.
By their numbers in this assay, from the lowest: compounds 3 and 2 (each within the scatter of the next); then compounds 4 and 1 (each within the scatter of the next).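

Removing the one-carbon link, so that the amide nitrogen carries the pyridin-2-yl ring directly, is not a silent change in this assay: it gives a number 13.9 percentage points higher from compound 2 to compound 4 (beyond the scatter). This is the only pair shown that differs in one place, and it reveals that, with the shared core held constant, the attachment on the amide nitrogen can by itself shift the read-out by more than repeat measurements would. No available evidence explains why the directly attached ring gives the higher number.

A single step cannot show whether the number would fall further with a longer chain between the amide nitrogen and the pyridine ring. It also leaves open whether the pyridine nitrogen matters, which a directly attached phenyl ring would help to test.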